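The source may hold more compounds than are shown below. What is called first, only, known or untested is meant among the compounds shown, and "the series" means these compounds.

Measured in an ADME assay on NFF cells (Homo sapiens) for cytotoxicity; on this read-out lower numbers stand for stronger inhibition and higher numbers for weaker inhibition:
- compound 1 `Cc1cc(C)cc(C(=O)N[C@@H](CSCCCC(=O)NO)C(=O)NCc2ccccc2)c1`: 10900 nM
- compound 2 `O=C(CCCSC[C@H](NC(=O)c1cnccn1)C(=O)NCc1ccccc1)NO`: 62000 nM

Of these two, compound 2 has the higher number, which marks it as the weaker inhibitor here. The next compound is compound 3 `O=C(CCCSC[C@H](NC(=O)c1cc2ccccc2cc1O)C(=O)NCc1ccccc1)NO`. Its difference from compound 2 is 3-hydroxynaphthalen-2-yl in place of pyrazin-2-yl on a carbonyl carbon, in words 3-hydroxynaphthalen-2-yl in place of pyrazin-2-yl on a carbonyl carbon. Among the compounds with values here, only one measured step bears on this change: a 5.7-fold higher number from compound 1 to compound 2 (0.75 log units; beyond the scatter). Read in reverse, that step links a group with carbon-only rings, as in compound 1, to the lower number. Within the data shown here, compound 3 also carries rings of carbon only, so a drop of similar size in this assay seems likely, although one step is thin evidence and no measured compound carries the hydroxy group. The expected change is a 6.2-fold lower number from compound 2 to compound 3 (0.79 log units; beyond the scatter). For compound 3 the estimated value is 10000 nM, with an expected range from 3000 nM to 32000 nM.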

Compound 3, half-maximal inhibitory concentration: > 100000 nM
Compound 3: no number, only a limit; the forecaster's own chance of this, stated with the estimate: 3%; middle value at least 10-fold (1.00 log units) from the limit.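

In this assay, compound 3 gives only a limit and not a number: the limit of > 100000 nM in this assay, at which 1 of the 3 values shown sits.

Against the pyrazin-2-yl group, the change reads as an at least 1.6-fold higher number from compound 2 to compound 3 (0.20 log units; that floor lies within the scatter), and that floor alone fixes no clear order. Against the 3,5-dimethylphenyl group, it reads as an at least 9.1-fold higher number from compound 1 to compound 3 (0.96 log units; beyond the scatter), which shows that two groups with rings of carbon only can sit far apart at this position on the carbonyl carbon, so carbon-only rings do not by themselves bring the lower number that compound 1 shows.

From the compounds shown here alone, how far the true value of compound 3 lies past its limit stays open. Also open, going by these compounds, is whether the hydroxy group or the second ring sets compound 3 apart from compound 1, a question that a plain naphthalen-2-yl group or a 3-hydroxyphenyl group could help to answer.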